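The compounds below may be only part of what the source reports. "The series", "measured", "known", "first", "only" and "open" are said of these compounds alone.

The measured compounds:
Compound 1 `N#C/C(=C\C=C(/Cl)c1ccc(Br)cc1)C(=O)c1c[nH]c2ccccc12`: in a functional assay on MCF7 cells (Homo sapiens) for cytotoxicity, read by sulforhodamine B assay, with a stated time of 48 h (a higher number here means that more compound is tolerated, a lower number that less compound is tolerated), compound 1 gives > 100000 nM, which is a limit of the assay.
Compound 2 `COc1ccc(/C(Cl)=C/C=C(\C#N)C(=O)c2c[nH]c3ccccc23)cc1OC`: in this assay compound 2 gives > 100000 nM, which is a limit of the assay.
Compound 3 `COc1ccc(/C(Cl)=C/C=C(\C#N)C(=O)c2c(C)[nH]c3ccccc23)cc1OC`: in this assay compound 3 gives > 100000 nM, which is a limit of the assay.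

None of these three values is a number, and what they show together is the limit of > 100000 nM in this assay, at which 3 of the 3 values shown sit. Compound 2 and compound 3 differ by methyl in place of hydrogen on an aromatic carbon; the step is a step that the two limits leave unreadable from compound 2 to compound 3, as both values are limits. The difference between the core of compound 1 and the core of compound 2 is not broken down here. Compound 4 `Cc1[nH]c2ccccc2c1C(=O)/C(C#N)=C/C=C(\Cl)c1ccc(Br)cc1` is not yet measured; it differs from compound 1 by methyl in place of hydrogen on an aromatic carbon, the same change as that between compound 2 and compound 3. Because the limit of > 100000 nM in this assay, at which 3 of the 3 values shown sit, holds for every measured compound, compound 4 is expected to sit at the limit too. For compound 4 the expected step is a step that the limit leaves unreadable from compound 1 to compound 4, resting on a step that the two limits leave unreadable from compound 2 to compound 3 being unreadable. For compound 4 in this assay the estimate is 150000 nM, between 50000 nM and 500000 nM.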

Compound 4, concentration lethal to 50% of the cells: > 100000 nM
Compound 4 was reported as a limit; the forecaster's own chance of this, stated with the estimate: 85%; the middle value is on the limit's open side.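

No new step can be read between compound 1 and compound 4, whose values are both limits of the assay, and the picture stays the same: the limit of > 100000 nM in this assay, at which 4 of the 4 values shown sit.

The compounds shown leave open where any of them would give an actual number in this assay, and so what methyl in place of hydrogen on an aromatic carbon does there.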